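The source may report more compounds than this note shows. Statements on the series, on what has been measured and on what is new or still open speak of the compounds shown alone.

Working notes on the chalcone-bearing series. The shared core of compound 1 `CNC(=O)c1cc(Oc2ccc(C(=O)/C=C/c3cccc([N+](=O)[O-])c3)cc2)ccn1` carries a 3-nitrophenyl group at the end of the chain, but in a functional assay on PC-3 cells (Homo sapiens) for cytotoxicity, read by MTT assay, with a stated time of 72 h (a higher number here means a weaker inhibitor, a lower number a stronger inhibitor), compound 1 gives "not determined" (no result reported), that is, no result reported. Compound 2 `CNC(=O)c1cc(Oc2ccc(C(=O)/C=C/c3ccc(C#N)cc3)cc2)ccn1` bears 4-cyanophenyl at the same place and in this assay compound 2 gives 3870 nM. Compound 3 `CNC(=O)c1cc(Oc2ccc(C(=O)/C=C/c3ccc(Cl)cc3Cl)cc2)ccn1` bears 2,4-dichlorophenyl, and in this assay compound 3 gives 9220 nM. Among the compounds with values here, compound 3 thus stands as the highest of the two numbers in hand, its nearest neighbour being compound 2, and the step of a 2.4-fold higher number from compound 2 to compound 3 (0.38 log units; beyond the scatter) is the only measured step.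

Compound 4 `CNC(=O)c1cc(Oc2ccc(C(=O)/C=C/c3ccc(F)cc3)cc2)ccn1` is not yet measured. The change from compound 3 is 4-fluorophenyl in place of 2,4-dichlorophenyl on a double-bonded chain carbon bound to a double-bonded chain carbon. Within the data shown here, the one measured step, a 2.4-fold higher number from compound 2 to compound 3 (0.38 log units; beyond the scatter), shows that exchanging one group on this chain carbon for another moves the number only modestly, and compound 4 returns to a single small group on the ring, closer in kind to compound 2 than to compound 3. The expectation is therefore a number somewhat below compound 3, in the direction of compound 2, with the step of a 1.8-fold lower number from compound 3 to compound 4 (0.27 log units; within the scatter) expected to stay near the edge of the scatter. For compound 4 in this assay the estimate is 5000 nM, with a range from 2000 nM to 12000 nM.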

Compound 4, half-maximal inhibitory concentration: 6140 nM
Compound 4: middle estimate off by 1.2-fold (0.09 log units), on the low side; measured number inside the range.
By their numbers in this assay, from the lowest: compounds 2, 4 and 3 (each within the scatter of the next, the first and the last beyond it).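

At the place on a double-bonded chain carbon bound to a double-bonded chain carbon, 4-fluorophenyl in place of 2,4-dichlorophenyl gives a 1.5-fold lower number from compound 3 to compound 4 (0.18 log units; within the scatter) in this assay, and fluoro in place of cyano on an aromatic carbon gives a 1.6-fold higher number from compound 2 to compound 4 (0.20 log units; within the scatter). Within the data shown here, the earlier compounds offered a single step, a 2.4-fold higher number from compound 2 to compound 3 (0.38 log units; beyond the scatter), which left open whether any exchange at this place would clear the scatter; compound 4 now stands within the scatter of both compound 2 and compound 3, so neither of its two new steps separates it from its neighbours, and the step from compound 2 to compound 3 remains the one reading that does. No measurement is at hand that would account for these numbers.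

The three aryl groups with numbers all keep a carbon-only six-membered aromatic ring with no hydrogen-bond donors, so the compounds shown leave open how an amine or a carboxylic acid on that ring would read in this assay. They also leave open whether a longer chain in place of the ring, or a methoxy group on it, would give a step beyond the scatter.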